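The source may report more compounds than this note shows. Statements on the series, on what has been measured and on what is new or still open speak of the compounds shown alone.

Working notes on the series. Compound 1 `COc1ccc(CN(C(=O)CSC(=S)N2CCc3ccccc32)c2cc(OC)c(OC)c(OC)c2)cc1` and compound 2 `COc1ccc(CN(C(=O)CSC(=S)N2CCc3cc(Br)ccc32)c2cc(OC)c(OC)c(OC)c2)cc1` share a core and differ by hydrogen in place of bromo on an aromatic carbon. In a functional assay on HCT-116 cells (Homo sapiens) for inhibition, read by CCK-8 assay, with a stated time of 48 h (on this read-out lower numbers stand for stronger inhibition and higher numbers for weaker inhibition), compound 1 gives 7710 nM, and compound 2 gives 8060 nM; the change gives a 1.0-fold lower number from compound 2 to compound 1 (0.02 log units; within the scatter). Compound 3 `COc1ccc(CN(C(=O)CSC(=S)N2CCN(C(=O)OC(C)(C)C)CC2)c2ccc(Br)cc2)cc1` carries a different core; how its core differs from that of compound 2 is not broken down here. For compound 3 this assay reports only a limit, > 20000 nM, which is the limit of > 20000 nM in this assay, at which 1 of the 3 values shown sits. Compound 4 `COc1ccc(CN(C(=O)CSC(=S)N2CCN(C(=O)OC(C)(C)C)CC2)c2ccccc2)cc1` is not yet measured and differs from compound 3 by hydrogen in place of bromo on an aromatic carbon. This is the same kind of change as that from compound 2 to compound 1, not the same: in compound 4 the site is on a six-membered aromatic ring of carbon only, para to a large group, whereas in compound 1 the ring is part of a fused or bridged system of two rings, meta to a fused ring and para to a fused ring. The expected step is a step that the limit leaves unreadable from compound 3 to compound 4, because a 1.0-fold lower number from compound 2 to compound 1 (0.02 log units; within the scatter) lies within the scatter. For compound 4 the estimated value in this assay is 30000 nM, expected between 12000 nM and 80000 nM, most likely again reported only as a limit.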

Compound 4, half-maximal inhibitory concentration: > 20000 nM
Compound 4: a limit, no number (the forecaster's own chance of this, stated with the estimate: 70%); the middle value does not contradict the limit.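

No step can be read between compound 3 and compound 4, since both are reported only as a limit in this assay: the limit of > 20000 nM in this assay, at which 2 of the 4 values shown sit.

The compounds shown leave open how strongly compound 3 and compound 4 act in this assay, and whether the change from 4-bromophenyl to phenyl alters the read-out on their shared core.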